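This account rests on a few compounds, and the source may have more. Where it says the series, first, only, none or still open, it means among the compounds named here.

In a functional assay on KB cells (Homo sapiens) for cytotoxicity (a higher number here means a weaker inhibitor, a lower number a stronger inhibitor), three compounds sharing one core have been measured, and they differ in the group on a nitrogen on an aromatic ring. Compound 2 `COc1ccc(S(=O)(=O)N2CCc3cccc(NC(=O)c4ccccc4)c32)cc1` gives 297 nM. Compound 3 `COc1ccc(S(=O)(=O)N2CCc3cccc(NS(=O)(=O)c4ccccc4)c32)cc1` gives 650 nM, the higher of the two exact numbers. The modest gap between them is a 2.2-fold higher number from compound 2 to compound 3 (0.34 log units; beyond the scatter). Compound 1 `COc1ccc(S(=O)(=O)N2CCc3cccc(NC(=O)Oc4ccccc4)c32)cc1` gives > 10000 nM, which is a limit of the assay and not a number.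

Compound 4 `COc1ccc(S(=O)(=O)N2CCc3cccc(NC(=O)N(C)c4ccccc4)c32)cc1` has yet to be measured. Its difference is methyl(phenyl)carbamoyl in place of phenylsulfonyl on a nitrogen on an aromatic ring. All three measured steps involve changes at this nitrogen. One is modest, a 2.2-fold higher number from compound 2 to compound 3 (0.34 log units; beyond the scatter), while the other two are large, an at least 33-fold lower number from compound 1 to compound 2 (1.52 log units; beyond the scatter) and an at least 15-fold lower number from compound 1 to compound 3 (1.18 log units; beyond the scatter). Exchanging the group here can therefore matter a great deal. By name, the entering group resembles the phenoxycarbonyl of compound 1 more than the benzoyl of compound 2, so a moderate rise in this assay is expected, with wide uncertainty. The expected change is a 2.3-fold higher number from compound 3 to compound 4 (0.36 log units; beyond the scatter). For compound 4 the estimated value is 1500 nM, with an expected range from 250 nM to 10000 nM.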

Compound 4, half-maximal inhibitory concentration: > 10000 nM
Compound 4 ended at the assay's limit (the forecaster's own chance of this, stated with the estimate: 25%); at least 6.6-fold (0.82 log units) between middle value and limit.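

Compound 4 gives > 10000 nM in this assay, which is a limit of the assay and not a number. Both readable steps into it are large, an at least 15-fold higher number from compound 3 to compound 4 (1.18 log units; beyond the scatter) and an at least 33-fold higher number from compound 2 to compound 4 (1.52 log units; beyond the scatter), so at this nitrogen on an aromatic ring, methyl(phenyl)carbamoyl does not keep the activity seen with the benzoyl of compound 2 or the phenylsulfonyl of compound 3. The loss is also no longer confined to the phenoxy of compound 1, since methyl(phenyl)amino on the carbonyl carbon in compound 4 ends at the same limit, whereas phenyl on that carbon in compound 2 does not: the limit of > 10000 nM in this assay, at which 2 of the 4 values shown sit.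

The step from compound 1 to compound 4 cannot be read, as both values are limits, so the compounds shown do not tell these two groups apart. On these data alone, it remains open how phenylamino on that carbonyl carbon, without the methyl of compound 4, or benzyl in place of the phenyl of compound 2, would read in this assay.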